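Series notes: aryl change on the aromatic nitrogen

The source may report more compounds than this note shows. Statements on the series, on what has been measured and on what is new or still open speak of the compounds shown alone.

Measured so far, in an ADME assay on L02 cells (Homo sapiens) for antiproliferative activity, read by MTT assay, with a stated time of 48 h; on this read-out lower numbers stand for stronger inhibition and higher numbers for weaker inhibition:
compound 1 `N#CC1=C(N)Oc2c(c3nc4ccccc4nc3c3ccccc23)C12C(=O)N(Cc1cnnn1-c1cccc(Cl)c1)c1ccccc12` gives 35200 nM.
compound 2 `COc1ccccc1-n1nncc1CN1C(=O)C2(C(C#N)=C(N)Oc3c2c2nc4ccccc4nc2c2ccccc32)c2ccccc21` gives > 50000 nM, which is a limit of this assay and not a number.
compound 3 `N#CC1=C(N)Oc2c(N)cc3nc4ccccc4nc3c2C12C(=O)N(Cc1cnnn1-c1ccccc1Cl)c1ccccc12` gives > 50000 nM, likewise a limit of this assay and not a number.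

Compound 3 thus stands at the limit of > 50000 nM in this assay, at which 2 of the 3 values shown sit. As far as these compounds go, its own number is unknown, and no ordering against compound 1 or compound 2 can be read from it. Compound 4 `N#CC1=C(N)Oc2c(N)cc3nc4ccccc4nc3c2C12C(=O)N(Cc1cnnn1-c1ccc([N+](=O)[O-])cc1)c1ccccc12` differs from compound 3 in one place only: 4-nitrophenyl in place of 2-chlorophenyl on an aromatic nitrogen. Going by the values given here, the single measured step that concerns an aryl swap on the aromatic nitrogen is an at least 1.4-fold higher number from compound 1 to compound 2 (0.15 log units; that floor lies within the scatter). Among the compounds with values here, it starts from the only numeric value in the set and runs into the limit, so it bounds the change from one side only and shows nothing beyond the scatter. No step beyond the scatter is therefore expected for compound 4 in this assay. The step expected in this assay is a number no higher from compound 3 to compound 4 (the limit leaves the size open). Compound 4 is estimated in this assay at 50000 nM, within 25000 nM to 100000 nM, with a real chance that the assay again returns only a limit.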

Compound 4, half-maximal inhibitory concentration: > 50000 nM
Compound 4: a limit, no number; the forecaster's own chance of this, stated with the estimate: 60%; the middle value sits exactly at the limit.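

In this assay, compound 3 and compound 4 both return only a limit and not a number, so no step can be read between them: the limit of > 50000 nM in this assay, at which 3 of the 4 values shown sit.

The compounds shown leave open the actual numbers of compound 3 and compound 4, and with them how 4-nitrophenyl compares with 2-chlorophenyl on the aromatic nitrogen.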